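The compounds below may be only part of what the source reports. "The series", "measured", "known", "first", "only" and "open" are said of these compounds alone.

Compound 1 `OC[C@H]1O[C@@H](n2cnc3c(NCc4ccc(F)cc4)ncnc32)[C@H](O)[C@@H]1O`: > 166000 nM
Compound 2 `OC[C@H]1O[C@@H](n2cnc3c(NCc4ccc(Cl)c(Cl)c4)ncnc32)[C@H](O)[C@@H]1O`: 145000 nM
Compound 3 `OC[C@H]1O[C@@H](n2cnc3c(NCc4ccc(F)cc4F)ncnc32)[C@H](O)[C@@H]1O`: > 166000 nM

These values come from a functional assay on G-361 cells (Homo sapiens) for antiproliferative activity, with a stated time of 72 h (a higher number here means a weaker inhibitor, a lower number a stronger inhibitor), and the series is marked by the limit of > 166000 nM in this assay, at which 2 of the 3 values shown sit. Compound 3 gives > 166000 nM, which is a limit and not a number. Compound 1 gives > 166000 nM, which is also a limit. Only compound 2 gives a true number, 145000 nM.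

Compound 4 `Cc1ccc(O)c(CNc2ncnc3c2ncn3[C@@H]2O[C@H](CO)[C@@H](O)[C@H]2O)c1` keeps the shared core but carries 2-hydroxy-5-methylphenyl in place of 2,4-difluorophenyl on a saturated chain carbon bound to a nitrogen on an aromatic ring. Among the compounds with values here, no measured compound carries this group, so the guidance is indirect.

Swaps at the same place gave an at least 1.1-fold lower number from compound 1 to compound 2 (0.05 log units; that floor lies within the scatter) and an at least 1.1-fold higher number from compound 2 to compound 3 (0.05 log units; that floor lies within the scatter), while a step that the two limits leave unreadable from compound 1 to compound 3 cannot be sized. None of these shows a large change, so only a modest move is expected in this assay, towards a lower number, and with real uncertainty. The expected step is an at least 1.8-fold lower number from compound 3 to compound 4 (0.26 log units; that floor lies within the scatter). For compound 4 the estimate is 90000 nM, with an expected range from 15000 nM to 166000 nM.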

Compound 4, half-maximal inhibitory concentration: > 166000 nM
Compound 4 ended at the assay's limit; the forecaster's own chance of this, stated with the estimate: 40%; middle value at least 1.8-fold (0.26 log units) away from the limit.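

Compound 4 shows that a phenyl ring carrying hydroxy and methyl groups, rather than only halogens, at this place still gives no readable activity in this assay. Against compound 2, the only compound with a true number, the change gives an at least 1.1-fold higher number from compound 2 to compound 4 (0.05 log units; that floor lies within the scatter), so no real separation from that value is shown, and the steps to compound 4 from compound 1 and from compound 3 join two limits and cannot be read. The new result adds to the crowding of the series at a single limit: the limit of > 166000 nM in this assay, at which 3 of the 4 values shown sit.

From the compounds shown here alone, it remains open whether any group on this saturated chain carbon can move the number far from that limit. An amine, a carboxylic acid or a longer chain in place of the substituted phenyl is untested among the compounds shown, and only a value well clear of the limit would give a step of readable size.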